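The source may hold more compounds than are shown below. What is called first, only, known or untested is meant among the compounds shown, and "the series" means these compounds.

Of the compounds shown here, three that share one core have so far been tested in an assay on Sf9 cells for inhibition of protein deacetylase HDAC6 (Homo sapiens), read by fluorescence, with a stated time of 40 min, tested at 100 nM; a higher number here means more inhibition at the concentration tested (going by the name of the read-out), a lower number less inhibition. Compound 1, `Cc1cccc(-c2nc(CNc3ccc(C(=O)NO)cc3)n(-c3ccccc3)n2)c1`, gives 64.1% in this assay. Compound 2, `O=C(NO)c1ccc(NCc2nc(-c3cccs3)nn2-c2ccc(O)cc2)cc1`, gives 79.6% in this assay, and compound 3, `O=C(NO)c1ccc(NCc2nc(-c3ccccc3)nn2-c2cccc(Cl)c2)cc1`, gives 62.3% in this assay. On these numbers compound 1 holds the second highest of the three values; its nearest neighbour is compound 3, whose value lies within the usual scatter of that of compound 1, so the two cannot be ordered, while compound 2 stands beyond the scatter above compound 1.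

Compound 4, `Cc1ccc(-c2nc(CNc3ccc(C(=O)NO)cc3)n(-c3ccccc3)n2)cc1`, has not yet been measured in this assay. It differs from compound 1 in one respect: 4-methylphenyl in place of 3-methylphenyl on an aromatic carbon. The two compounds hold the same atoms joined differently, and the exchange neither adds nor removes a hydrogen-bond donor or acceptor. Among the compounds with values here, no measured pair among the three compounds shows what such an exchange does in this assay, so there is no step to lean on. Starting from compound 1 with its value of 64.1%, the expected step from compound 1 to compound 4 is a number 1.1 percentage points lower from compound 1 to compound 4 (within the scatter), which is meant as no step beyond the scatter in either direction. Compound 4 is accordingly expected to give about 63% in this assay, within an estimated range from 47% to 78%.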

Compound 4, a percentage reported as inhibition, at one concentration (the size of the read-out at that concentration, not a potency): 62.2%
Beside the measured number, compound 4's estimate is 0.8 percentage points above it; measured number inside the range.
By their numbers in this assay, from the lowest: compounds 4, 3 and 1 (each within the scatter of the next); then compound 2.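

In this assay, within the data shown here, the exchange of 3-methylphenyl for 4-methylphenyl on the aromatic carbon of the five-membered ring gives the first step that can be read at this position: a number 1.9 percentage points lower from compound 1 to compound 4 (within the scatter). Moving the methyl group around this phenyl ring therefore leaves the read-out unchanged within the scatter, and the two isomers cannot be told apart at the single concentration tested. Among these compounds, since both compounds carry the same atoms and the same count of hydrogen-bond donors and acceptors in this group, the step isolates the placement of the methyl group alone, which none of the earlier compounds could do. No evidence at hand bears on why the two compounds read alike.

The compounds shown leave open whether a carboxylic acid or an amine on this phenyl ring, or a longer chain such as propyl in place of methyl, would shift the value beyond the scatter. They also leave open whether the two isomers would still read alike across a full concentration series, as a single-concentration read-out is not a potency.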